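The source may hold more compounds than are shown below. What is called first, only, known or untested is meant among the compounds shown, and "the series" means these compounds.

Measured in a functional assay on P388 cells (Mus musculus); a higher number here means a weaker inhibitor, a lower number a stronger inhibitor:
- Compound 1 `O=C(/C=C/c1ccc(F)cc1)Oc1ccc(/C=C2\CCCCC2=O)cc1` gives > 50000 nM, a limit and not a number
- Compound 2 `COc1ccc(/C=C/C(=O)Oc2ccc(/C=C3\CCCC(CN(C)C)C3=O)cc2)cc1` gives 2410 nM
- Compound 3 `O=C1CCCC/C1=C\c1ccc(OC(=O)c2ccc(Cl)cc2)cc1` gives 25500 nM

Only two of these three results are actual numbers. Compound 3, at 25500 nM, holds the higher of them, which makes it the weaker inhibitor of the pair. Compound 2, at 2410 nM, lies lower by a gap well beyond the usual scatter. Compound 1 stays a limit at > 50000 nM.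

The next compound is compound 4 `O=C(CCc1ccccc1)Oc1ccc(/C=C2\CCCCC2=O)cc1`, which has not yet been measured. It carries phenethyl in place of 4-chlorophenyl on a carbonyl carbon. The group that leaves and the group that enters each hold one six-membered aromatic ring of carbon only, and neither has hydrogen-bond donors or acceptors. No measured pair shows a change of this kind in this assay, so the expectation starts from compound 3 at 25500 nM. No step beyond the scatter is expected, and either direction remains possible. The estimated step is a 1.2-fold higher number from compound 3 to compound 4 (0.07 log units; within the scatter). For compound 4 the estimated value is 30000 nM, with an expected range from 12000 nM to 65000 nM.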

Compound 4, half-maximal inhibitory concentration: 21900 nM
Beside the measured number, compound 4's estimate is 1.4-fold (0.14 log units) above it; low and high end bracket the measured number.
By their numbers in this assay, from the lowest: compound 2; then compounds 4 and 3 (each within the scatter of the next). At a limit, above all of these: compound 1.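

In this assay, going by these compounds alone, the first step at this position, on a carbonyl carbon, is a 1.2-fold lower number from compound 3 to compound 4 (0.07 log units; within the scatter), so phenethyl in place of 4-chlorophenyl produces no change that can be told apart from the scatter. The chlorine leaves and the group grows from 7 heavy atoms to 8, while both groups hold one six-membered aromatic ring of carbon only, and this particular exchange leaves the number where it was. Within the data shown here, compound 1 remains a limit and not a number, so it adds no step to this reading: the limit of > 50000 nM in this assay, at which 1 of the 4 values shown sits.

The compounds shown leave open what an amine or a carboxylic acid on this carbonyl carbon would do to the number, and how a longer chain would compare with phenethyl. The loss of the chlorine and the gain of the chain also arrive together in this one step, and a plain phenyl in this place would be needed to read the two apart.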